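The source may hold more compounds than are shown below. What is called first, only, known or untested is meant among the compounds shown, and "the series" means these compounds.

Working notes on the series. The three measured compounds share one core and differ in the chain and in the aryl group. Compound 1 `CCC/C=C/c1c(C(C)C)nc(C(C)C)c(CO)c1-c1ccc(S(C)(=O)=O)cc1` gives 14% in an assay on CHO cells for inhibition of Glucagon receptor (Homo sapiens), tested at 20 uM; on this read-out lower numbers stand for less inhibition and higher numbers for more inhibition at the one concentration tested (going by the name of the read-out). Compound 2 `CCCCCc1c(C(C)C)nc(C(C)C)c(CO)c1-c1ccc(O)cc1` gives 24% in this assay, a number within the usual scatter of compound 1 and above that of compound 3 `CCCCCc1c(C(C)C)nc(C(C)C)c(C)c1-c1ccccc1O`, which gives 11% in this assay, a gap beyond the scatter. All three numbers are small at the single concentration tested. Compound 4 `CCCCCc1c(C(C)C)nc(C(C)C)c(CO)c1-c1ccc(Cl)cc1Cl` is not yet measured and differs from compound 2 in one place: 2,4-dichlorophenyl in place of 4-hydroxyphenyl on an aromatic carbon. Going by the values given here, no measured pair shows this change, so no step can be read from the data. The expected step is a number 4 percentage points lower from compound 2 to compound 4 (within the scatter), none beyond the scatter. Compound 4 is estimated at 20% in this assay, with a range from 5% to 40%.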

Compound 4, a percentage reported as inhibition, at one concentration (the size of the read-out at that concentration, not a potency): 8%
For compound 4 the middle estimate is 12 percentage points above the measured one; measured number inside the range.
By their numbers in this assay, from the lowest: compounds 4, 3, 1 and 2 (each within the scatter of the next, the first and the last beyond it).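

On an aromatic carbon opposite the ring nitrogen, 2,4-dichlorophenyl in place of 4-hydroxyphenyl gives a number 16 percentage points lower from compound 2 to compound 4 (beyond the scatter) in this assay, the first step readable in the series. The group that enters carries no hydrogen-bond donor or acceptor, whereas the group that leaves carries one of each, but this single pair cannot separate losing the hydroxyl from adding the two chlorines. Nothing on hand accounts for the step. Still open, on these data alone, is whether a phenyl with a single chlorine, an aminophenyl or a carboxyphenyl at this place would give a higher or lower number.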